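Swapping trifluoromethyl for methoxy in a small series

The source may hold more compounds than are shown below. What is called first, only, known or untested is meant among the compounds shown, and "the series" means these compounds.

In a functional assay on HCT-116 cells (Homo sapiens) for antiproliferative activity, read by MTT assay, with a stated time of 72 h (on this read-out higher numbers stand for weaker inhibition and lower numbers for stronger inhibition), compound 1 (`C=CC(=O)Nc1nc(-c2ccccc2)cs1`) gives 18600 nM, compound 2 (`C=CC(=O)Nc1nc(-c2ccc(C)cc2)cs1`) gives 15300 nM, and compound 3 (`C=CC(=O)Nc1nc(-c2ccc(C(F)(F)F)cc2)cs1`) gives 4000 nM, the lowest number of the three. Compound 4 (`C=CC(=O)Nc1nc(-c2ccc(OC)cc2)cs1`) carries methoxy in place of trifluoromethyl on an aromatic carbon, para to a large group: methoxy in place of trifluoromethyl on an aromatic carbon. Among the compounds with values here, the steps that bear on this are a 4.7-fold lower number from compound 1 to compound 3 (0.67 log units; beyond the scatter) and a 3.8-fold lower number from compound 2 to compound 3 (0.58 log units; beyond the scatter), whereas methyl made little difference, with a 1.2-fold lower number from compound 1 to compound 2 (0.08 log units; within the scatter). Within the data shown here, no measured step involves methoxy, so a modest step to a higher number is expected in this assay, back towards compound 2 at 15300 nM. The expected change is a 3.5-fold higher number from compound 3 to compound 4 (0.54 log units; beyond the scatter). Compound 4 is estimated at 14000 nM, within an expected range of 6500 nM to 28000 nM.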

Compound 4, half-maximal inhibitory concentration: 8000 nM
Compound 4: the middle estimate sits 1.8-fold (0.24 log units) above what was measured; low and high end bracket the measured number.
By their numbers in this assay, from the lowest: compounds 3, 4, 2 and 1 (each within the scatter of the next, the first and the last beyond it).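

In this assay, methoxy on this aromatic carbon, para to a large group, joins trifluoromethyl as a replacement for hydrogen whose effect exceeds the scatter, with a 2.3-fold lower number from compound 1 to compound 4 (0.37 log units; beyond the scatter). The other two steps, a 2.0-fold higher number from compound 3 to compound 4 (0.30 log units; within the scatter) and a 1.9-fold lower number from compound 2 to compound 4 (0.28 log units; within the scatter), both stay within the scatter, so the methoxy compound cannot be told apart from either the trifluoromethyl or the methyl compound, even though those two differ from each other beyond it. No evidence is available that would account for this. From the compounds shown here alone, how an amine or a carboxylic acid on this carbon would compare remains open.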